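The source may hold more compounds than are shown below. What is called first, only, known or untested is meant among the compounds shown, and "the series" means these compounds.

Measured compounds in a functional assay on HepG2 cells (Homo sapiens) for inhibition, read by MTT assay, with a stated time of 72 h; a higher number here means a weaker inhibitor, a lower number a stronger inhibitor:
- compound 1 `CN(C(=O)NC(=O)c1ccc(F)c(F)c1)c1nc(C(F)(F)F)c(C(=O)N/N=C/c2ccccc2C(F)(F)F)s1` gives 10.4 ug/mL
- compound 2 `CN(C(=O)NC(=O)c1ccc(F)c(F)c1)c1nc(C(F)(F)F)c(C(=O)N/N=C/c2cccc(C(F)(F)F)c2)s1` gives 5.6 ug/mL
- compound 3 `CN(C(=O)NC(=O)c1ccc(F)c(F)c1)c1nc(C(F)(F)F)c(C(=O)N/N=C/c2ccc([N+](=O)[O-])cc2)s1` gives 6.23 ug/mL

Compound 1 is the reference here. Against the other two it shows a 1.9-fold lower number from compound 1 to compound 2 (0.27 log units; within the scatter) and a 1.7-fold lower number from compound 1 to compound 3 (0.22 log units; within the scatter), both within the scatter, and between compound 2 and compound 3 there is a 1.1-fold higher number from compound 2 to compound 3 (0.05 log units; within the scatter), again within the scatter. On the numbers shown the three compounds cannot be told apart in this assay.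

Compound 4 `CN(C(=O)NC(=O)c1cccc([N+](=O)[O-])c1)c1nc(C(F)(F)F)c(C(=O)N/N=C/c2ccccc2C(F)(F)F)s1` is the next structure to be measured. It differs from compound 1 in one place: 3-nitrophenyl in place of 3,4-difluorophenyl on a carbonyl carbon. Cut one bond further out, the change reads (3,4-difluorophenyl)carbonyl to (3-nitrophenyl)carbonyl.

None of the three measured steps touches this part of the molecule; all of them vary the aryl group on the carbon with a double bond to nitrogen, on the other side of the shared core, and each stayed within the scatter. Among the measured compounds shown here, there is therefore no measured step that bears directly on the change from compound 1 to compound 4. The one thing the series does show is that aryl swaps of this kind, at least on the hydrazone side, have not moved the number beyond the scatter, so the expectation is a step of no more than the scatter in this assay, with no direction preferred.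

For compound 4 the number expected in this assay is 9.5 ug/mL, range 4 ug/mL to 24 ug/mL, which is the estimated step of a 1.1-fold lower number from compound 1 to compound 4 (0.04 log units; within the scatter).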

Compound 4, half-maximal inhibitory concentration: 4.8 ug/mL
Estimate against measurement, compound 4: 2.0-fold (0.30 log units) above, and the stated range covers the measured number.
By their numbers in this assay, from the lowest: compounds 4, 2, 3 and 1 (each within the scatter of the next, the first and the last beyond it).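

In this assay, among the compounds shown here, the change from 3,4-difluorophenyl to 3-nitrophenyl on the carbonyl carbon gives a 2.2-fold lower number from compound 1 to compound 4 (0.34 log units; beyond the scatter) and is the only step printed as beyond the scatter, though it is modest. The steps among compound 1, compound 2 and compound 3 all vary the aryl group on the carbon with a double bond to nitrogen and all stay within the scatter, so the aryl group on the carbonyl carbon is the one place shown where a single change moves the number past the scatter, on one pair only. Nothing available explains this step.

The change removes two fluorines and brings in a nitro group at once, and this single pair cannot show which part of the exchange carries the step, nor whether it holds with the aryl groups of compound 2 and compound 3 on the other side of the shared core. Also open, from the compounds shown here alone, is how the number responds when the carbonyl carbon bears a phenyl ring carrying an amine or a carboxylic acid, or a longer alkyl chain instead of a phenyl ring.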